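Shortening the pentyl chain on compound 1

A few compounds are considered here, and "the series" means these few. Any claim that something is new, unique, unknown or untested is made for them only; others in the source may bear on it.

Compound 1 `CCCCCc1ccc(CCc2cc3cn([C@H]4C[C@H](O)[C@@H](CO)O4)c(=O)nc3o2)cc1`: >= 470000 nM
Compound 2 `CCCCCc1ccc(-c2cc3cn([C@H]4C[C@H](O)[C@@H](CO)O4)c(=O)nc3o2)cn1`: 100000 nM
Compound 3 `CCCCCc1ccc(-c2cc3cn([C@H]4C[C@H](O)[C@@H](CO)O4)c(=O)nc3o2)cc1`: > 1300 nM

Of the compounds shown here, three share one core and have been tested in an ADME assay on HEL cells (Homo sapiens) for cytotoxicity, with a stated time of 3 days; a lower number here means that less compound is tolerated, a higher number that more compound is tolerated. Compound 1 gives only a limit of the assay, >= 470000 nM, and so sits at the limit of >= 470000 nM in this assay, at which 1 of the 3 values shown sits. Compound 2 gives 100000 nM. Compound 3 likewise gives only a limit, > 1300 nM, and stands at the limit of > 1300 nM in this assay, at which 1 of the 3 values shown sits. No single-change pair among these three is available as a measured step.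

Compound 4 `Cc1ccc(CCc2cc3cn([C@H]4C[C@H](O)[C@@H](CO)O4)c(=O)nc3o2)cc1` differs from compound 1 by hydrogen in place of butyl on a saturated chain carbon bound to an aromatic carbon, which read one bond further out is pentyl to methyl. For the measured compounds named here, no measured step covers this change. In this assay the step of a number no higher from compound 1 to compound 4 (the limit leaves the size open) is expected to be none beyond the scatter, so compound 4 is estimated at 470000 nM, within 150000 nM to 1000000 nM.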

Compound 4, minimum cytotoxic concentration: 540000 nM
For compound 4 the middle estimate is 1.1-fold (0.06 log units) below the measured one; measured number inside the range.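

Compound 1 is recorded only as a limit, and the step from it to compound 4 cannot be read. The compounds shown leave open whether going from pentyl to methyl changes the result in this assay at all.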